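Replacing a trifluoromethyl group with hydrogen on a diaryl urea

This account rests on a few compounds, and the source may have more. Where it says the series, first, only, none or still open, it means among the compounds named here.

Measured compounds:
Compound 1 `O=C(Nc1cccc(-n2cc(-c3ccncc3)c(-c3cc(O)cc(Cl)c3)n2)c1)Nc1ccc(Cl)c(Cl)c1` in a functional assay on K562 cells (Homo sapiens) for inhibition, read by sulforhodamine B assay, with a stated time of 48 h, tested at 0.01 uM (on this read-out higher numbers stand for a weaker effect at the one concentration tested and lower numbers for a stronger effect), gives 107%.
Compound 2 `COc1cc(Cl)cc(-c2nn(-c3cccc(NC(=O)Nc4ccc(Cl)c(C(F)(F)F)c4)c3)cc2-c2ccncc2)c1` in this assay gives 94%.
Compound 3 `COc1cc(Cl)cc(-c2nn(-c3cccc(NC(=O)Nc4cc(C(F)(F)F)cc(C(F)(F)F)c4)c3)cc2-c2ccncc2)c1` in this assay gives 97%.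

Of these three numbers, compound 3 has the second highest. Its nearest neighbour is compound 2, whose value is lower, and its furthest is compound 1, whose value is higher; both gaps are within the scatter of the measurement, so the three compounds cannot be told apart on this read-out.

Compound 4 `COc1cc(Cl)cc(-c2nn(-c3cccc(NC(=O)Nc4cccc(C(F)(F)F)c4)c3)cc2-c2ccncc2)c1` has not yet been measured in this assay. It differs from compound 3 in one place:

hydrogen in place of trifluoromethyl on an aromatic carbon

Among the compounds with values here, no step between two measured compounds is available to show what this kind of change does. Because the three measured compounds, including compound 3 with 97%, all sit at the top of the scale within the scatter of one another, no step beyond the scatter in either direction is expected from compound 3 to compound 4 in this assay, and the expected step is a number 1 percentage points higher from compound 3 to compound 4 (within the scatter). Compound 4 is estimated to give 98% in this assay, with a range from 85% to 110%.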

Compound 4, a percentage reported as activity, at one concentration (the size of the read-out at that concentration, not a potency): 104%
For compound 4 the middle estimate is 6 percentage points below the measured one; low and high end bracket the measured number.
By their numbers in this assay, from the lowest: compounds 2, 3, 4 and 1 (each within the scatter of the next, the first and the last beyond it).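

In this assay, within the data shown here, two single changes on the aromatic ring of the urea can now be read, where the earlier compounds offered no such step: hydrogen in place of trifluoromethyl on an aromatic carbon (a number 7 percentage points higher from compound 3 to compound 4 (within the scatter)) and hydrogen in place of chloro on an aromatic carbon (a number 10 percentage points higher from compound 2 to compound 4 (within the scatter)). Both steps lie within the scatter, so at the one concentration tested, neither the trifluoromethyl group lost from compound 3 nor the chloro group lost from compound 2 can be shown to matter on this read-out, and the remaining trifluoromethyl group alone gives a number that cannot be told apart from theirs. Nothing measured here offers an explanation for these two steps.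

All of these compounds sit so close together that this assay leaves open whether the two changes would separate at any other concentration or on any compound with a clearer effect. It also leaves open what an amine or a carboxylic acid on that same aromatic carbon would give, and whether either would produce a step beyond the scatter.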